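A few compounds are considered here, and "the series" means these few. Any claim that something is new, unique, unknown or untested is made for them only; others in the source may bear on it.

Measured values in a functional assay on A549 cells (Homo sapiens) for antiproliferative activity, read by MTT assay, with a stated time of 72 h; a higher number here means a weaker inhibitor, a lower number a stronger inhibitor:
compound 1 `COc1cc2ncnc(Nc3ccc(F)c(Cl)c3)c2cc1OCCCCC(=O)Nc1ccc(S(N)(=O)=O)cc1` — 15500 nM
compound 2 `C#Cc1cccc(Nc2ncnc3cc(OC)c(OCCCCC(=O)Nc4ccc(S(N)(=O)=O)cc4)cc23)c1` — 7720 nM
compound 3 `NS(=O)(=O)c1ccc(NC(=S)Nc2ccc3ncnc(Nc4ccc(F)c(Cl)c4)c3c2)cc1` — > 40000 nM, a limit of the assay, not a number

Going by the values given here, compound 3 therefore stands only at the limit (the limit of > 40000 nM in this assay, at which 1 of the 3 values shown sits), the one such value among the three, and its true value is unknown beyond that. Compound 4 `NS(=O)(=O)c1ccc(NC(=S)Nc2ccc3ncnc(Nc4cccc(Cl)c4F)c3c2)cc1` differs from it only in the aryl group on the nitrogen: 3-chloro-2-fluorophenyl in place of 3-chloro-4-fluorophenyl on a nitrogen on an aromatic ring. Among the compounds with values here, the one measured step that bears on an aryl swap at this nitrogen is a 2.0-fold lower number from compound 1 to compound 2 (0.30 log units; within the scatter), which stays within the scatter. A change within the scatter is thus expected here too, a step that the limit leaves unreadable from compound 3 to compound 4. For compound 4 the estimate in this assay is 45000 nM, with a range from 15000 nM to 130000 nM, and a limit is again the likely report.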

Compound 4, half-maximal inhibitory concentration: > 40000 nM
Compound 4 ended at the assay's limit; the forecaster's own chance of this, stated with the estimate: 70%; the middle value lies beyond the limit too.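

In this assay, going by these compounds alone, compound 3 and compound 4 both sit at a limit, not a number, so no step between them can be read: the limit of > 40000 nM in this assay, at which 2 of the 4 values shown sit.
Going by these compounds, how far 3-chloro-2-fluorophenyl in place of 3-chloro-4-fluorophenyl shifts the true values stays open.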